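Aryl variation on the shared core: projecting compound 4

The source may hold more compounds than are shown below. What is called first, only, known or untested is meant among the compounds shown, and "the series" means these compounds.

Measured compounds:
- compound 1 `C[C@H](Nc1ncnc2[nH]cnc12)c1nn(-c2cccc(F)c2)c2cc(F)ccc12`: 33%
- compound 2 `C[C@H](Nc1ncnc2[nH]cnc12)c1nn(-c2ccc(C#N)cc2)c2cc(F)ccc12`: 57%
- compound 3 `C[C@H](Nc1nc(N)nc(N)c1C#N)c1nn(-c2cccnc2)c2cc(C(F)(F)F)ccc12`: 36%

The read-out throughout is a functional assay on HepG2 cells (Homo sapiens) for inhibition, read by sulforhodamine B assay, with a stated time of 72 h, tested at 10 uM; on this read-out higher numbers stand for more inhibition at the one concentration tested (going by the name of the read-out) and lower numbers for less inhibition. Compound 2 stands highest of the three numbers: compound 3 lies nearest, a number beyond the scatter below it, and compound 1 lies furthest. Compound 3 differs from compound 2 in more than one place, so its value is noted only as a comparison, not as a step.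

Compound 4 `C[C@H](Nc1ncnc2[nH]cnc12)c1nn(-c2cccc(S(C)(=O)=O)c2)c2cc(F)ccc12` is the next candidate. It differs from compound 2 in a single place: 3-(methylsulfonyl)phenyl in place of 4-cyanophenyl on an aromatic nitrogen

For the measured compounds named here, the one measured step that bears on this change is the aryl exchange on the same aromatic nitrogen, a number 24 percentage points higher from compound 1 to compound 2 (beyond the scatter), a modest gain. Nothing measured covers the 3-(methylsulfonyl)phenyl group itself, so the direction of the new step is not fixed by data. Given that a change of aryl group at this position has already moved the number beyond the scatter once, a shift of similar size in either direction is plausible, and an outcome somewhere between compound 1 and compound 2 is taken as the central case. Compound 4 is therefore expected to land at 45%, within 25% to 65%, which means an estimated step of a number 12 percentage points lower from compound 2 to compound 4 (beyond the scatter).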

Compound 4, a percentage reported as inhibition, at one concentration (the size of the read-out at that concentration, not a potency): 23%
Compound 4: the middle estimate sits 22 percentage points above what was measured, and the stated range ends above it.
By their numbers in this assay, from the lowest: compounds 4, 1 and 3 (each within the scatter of the next, the first and the last beyond it); then compound 2.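

In this assay, changing the aryl group on the aromatic nitrogen can lower the number as well as raise it: 3-(methylsulfonyl)phenyl in place of 4-cyanophenyl gives a number 34 percentage points lower from compound 2 to compound 4 (beyond the scatter). The gain seen with compound 2 therefore does not extend to every substituted phenyl at this place, and methylsulfonyl in place of fluoro on the same aromatic carbon gives a number 10 percentage points lower from compound 1 to compound 4 (within the scatter), so these two groups are not separated by this read-out. No measurement at hand gives a reason for either step.

Still open, as far as these compounds go, is whether the higher number of compound 2 belongs to the nitrile itself or to where it sits on the phenyl ring, since the nitrile and its placement change together across these compounds; 3-cyanophenyl and 4-(methylsulfonyl)phenyl would pull the two apart. Also open, from the compounds shown here alone, is how groups of another kind behave on this phenyl ring, such as an amine or a carboxylic acid, and whether the 4-cyanophenyl gain carries over to the other core of compound 3.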